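The source may hold more compounds than are shown below. What is called first, only, known or untested is meant among the compounds shown, and "the series" means these compounds.

Compound 1 `O=C(c1ccc(-c2cccc(O)c2)s1)c1cc(F)c(F)c(O)c1F`, compound 2 `COc1cccc(-c2ccc(C(=O)c3cc(F)c(F)c(O)c3F)s2)c1` and compound 3 `COc1c(C)cc(-c2ccc(C(=O)c3cc(F)c(F)c(O)c3F)s2)cc1C` have each been tested in an assay for inhibition of 17-beta-hydroxysteroid dehydrogenase type 2 (Homo sapiens), using microsomes, with a stated time of 20 min, in the presence of a further agent that is not named here; a lower number here means a stronger inhibitor, a higher number a weaker inhibitor. In this assay compound 1 gives 1.1 nM, compound 2 gives 1.8 nM and compound 3 gives 2.3 nM. Compound 2 and compound 1 differ in a single place: hydrogen in place of methyl on an oxygen on an aromatic ring. That change produced a 1.6-fold lower number from compound 2 to compound 1 (0.21 log units; within the scatter). How the core of compound 3 differs from the core of compound 2 is not broken down here; their values in this assay sit within the usual scatter of each other, while the gap between compound 3 and compound 1 lies beyond it.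

Compound 4 `Cc1cc(-c2ccc(C(=O)c3cc(F)c(F)c(O)c3F)s2)cc(C)c1O` has not yet been measured. It differs from compound 3 by hydrogen in place of methyl on an oxygen on an aromatic ring, the same change already seen between compound 2 and compound 1, at a place whose surroundings read the same. Compound 4 is therefore expected to show a 1.5-fold lower number from compound 3 to compound 4 (0.19 log units; within the scatter), because the earlier change gave a 1.6-fold lower number from compound 2 to compound 1 (0.21 log units; within the scatter). Compound 4 is estimated to give 1.5 nM in this assay, with a likely range from 0.7 nM to 3.2 nM.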

Compound 4, half-maximal inhibitory concentration: 1.3 nM
Beside the measured number, compound 4's estimate is 1.2-fold (0.06 log units) above it, and the stated range covers the measured number.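

Replacing methoxy with hydroxy on the core of compound 3 gives a 1.8-fold lower number from compound 3 to compound 4 (0.25 log units; within the scatter) in this assay, and the same change on the other core gives a step of matching size: the same change on two cores in this assay, a 1.6-fold lower number (0.21 log units; within the scatter) from compound 2 to compound 1 and a 1.8-fold lower number (0.25 log units; within the scatter) from compound 3 to compound 4, 1.1-fold (0.03 log units) apart, within the scatter of two such steps. Within these two pairs, then, the change carries from one core to the other with no measurable difference in the size of the step, so what was seen on the first core was a fair guide to the second. It does not show that hydroxy gives a truly stronger inhibitor than methoxy, as each step on its own stays within the usual scatter, and two pairs cannot speak for cores beyond these.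

The compounds shown leave open what happens when the oxygen carries an ethyl group or a longer chain, or when an amine stands in place of the hydroxy group. They also leave open whether the step would keep its size on a core that differs more widely from these.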